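Swapping isopropyl for methyl on the shared core

This account rests on a few compounds, and the source may have more. Where it says the series, first, only, none or still open, it means among the compounds named here.

Among the compounds with values here, in an ADME assay on microsomes from liver (Mus musculus) for metabolic stability, read by LC-MS, using NADPH, tested at 1 uM (on this read-out higher numbers stand for fast clearance and lower numbers for slow clearance), compound 2 (`CC(C)c1cnc(NC(=O)CCCOc2ccccc2)s1`) gives 740 mL.min-1.g-1, the higher of the two numbers so far, while compound 1 (`N#Cc1cnc(NC(=O)CCCOc2ccccc2)s1`) gives 114 mL.min-1.g-1. Compound 3 (`Cc1cnc(NC(=O)CCCOc2ccccc2)s1`) carries methyl in place of isopropyl on an aromatic carbon. Within the data shown here, one measured step bears on this change. It alters the same place: isopropyl in place of cyano gives a 6.5-fold higher number from compound 1 to compound 2 (0.81 log units; beyond the scatter). That step shows that the group at this place can move the number in this assay. It cannot show where methyl will fall, since neither measured compound carries it. A landing between the two measured values seems the most reasonable expectation. The expected change is a 2.5-fold lower number from compound 2 to compound 3 (0.39 log units; beyond the scatter), a move toward slower clearance. Compound 3 is estimated at 300 mL.min-1.g-1, with an expected range from 130 mL.min-1.g-1 to 680 mL.min-1.g-1.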

Compound 3, intrinsic clearance in microsomes: 815 mL.min-1.g-1
The estimate for compound 3 lay 2.7-fold (0.43 log units) below the measured number, outside the stated range (above it).
By their numbers in this assay, from the lowest: compound 1; then compounds 2 and 3 (each within the scatter of the next).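

In this assay, putting methyl in place of isopropyl gives a 1.1-fold higher number from compound 2 to compound 3 (0.04 log units; within the scatter), so these two groups cannot be told apart on this read-out, and the size of the group, going from isopropyl to methyl, makes no measurable difference here. Methyl in place of cyano gives a 7.1-fold higher number from compound 1 to compound 3 (0.85 log units; beyond the scatter), which repeats the gap first seen with isopropyl, so among these three groups only the cyano compound, compound 1, stands apart, at the slow-clearance end. Nothing measured here explains why the cyano compound differs from the other two.

As far as these compounds go, it remains open whether another group at this place, such as a primary amide or a chlorine atom, would fall near compound 1 or near compounds 2 and 3. Also open, from the compounds shown here alone, is whether the same picture would hold with a longer chain elsewhere on the shared core.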